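Nitro for trifluoromethyl on the acyl ring: compound 3

The compounds below may be only part of what the source reports. "The series", "measured", "known", "first", "only" and "open" are said of these compounds alone.

Measured so far:
Compound 1, `CN(C(=O)NC(=O)c1ccccc1F)c1nc(C(F)(F)F)c(C(=O)N/N=C/c2ccccc2C(F)(F)F)s1` — 4.67 ug/mL
Compound 2, `CN(C(=O)NC(=O)c1cccc(C(F)(F)F)c1)c1nc(C(F)(F)F)c(C(=O)N/N=C/c2ccccc2C(F)(F)F)s1` — 7.29 ug/mL

Among the measured compounds shown here, in a functional assay on BCG823 cells (Homo sapiens) for inhibition, read by MTT assay, with a stated time of 72 h (a lower number here means a stronger inhibitor, a higher number a weaker inhibitor), compound 2 stands as the higher of the two numbers measured, and its only neighbour is compound 1, which lies within the scatter of it. For the measured compounds named here, the single measured step, a 1.6-fold higher number from compound 1 to compound 2 (0.19 log units; within the scatter), changes the acyl ring in a different way and is itself within the scatter, so it says little more than that this end of the molecule has tolerated a swap of substituent without a clear shift in this assay.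

Compound 3, `CN(C(=O)NC(=O)c1cccc([N+](=O)[O-])c1)c1nc(C(F)(F)F)c(C(=O)N/N=C/c2ccccc2C(F)(F)F)s1`, differs from compound 2 only at that ring: nitro in place of trifluoromethyl on an aromatic carbon. Going by the values given here, no measured pair shows this particular exchange, so the expectation rests on the absence of any step beyond the scatter in the data.

Compound 3 is therefore expected to sit close to compound 2, with an estimated step of a 1.1-fold lower number from compound 2 to compound 3 (0.05 log units; within the scatter), and its value in this assay is estimated at 6.5 ug/mL with a range from 2.5 ug/mL to 16 ug/mL.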

Compound 3, half-maximal inhibitory concentration: 3.97 ug/mL
For compound 3 the middle estimate is 1.6-fold (0.21 log units) above the measured one, and the stated range covers the measured number.
By their numbers in this assay, from the lowest: compounds 3, 1 and 2 (each within the scatter of the next).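

In this assay, nitro in place of trifluoromethyl on the aromatic carbon of the acyl ring gives a 1.8-fold lower number from compound 2 to compound 3 (0.26 log units; within the scatter), and the wider comparison of 3-nitrophenyl with 2-fluorophenyl gives a 1.2-fold lower number from compound 1 to compound 3 (0.07 log units; within the scatter). The acyl ring has now carried three different substituted forms with no step beyond the scatter, and the exchange of a group with no hydrogen-bond acceptors for one with two acceptors is also among the steps that stay within it, so no preference among these three acyl rings can be read from this assay. Nothing available explains why these numbers stay so close, and no measurement of any property of these groups bears on the result.

The compounds shown leave open whether this position would stay as undemanding with an amine, a carboxylic acid or a longer alkyl chain on the acyl ring, since all three substituents shown are fluorine-bearing or nitro groups. They also leave open how the number responds to changes elsewhere, as the 2-(trifluoromethyl)phenyl ring at the other end and the rest of the shared core are the same in all three compounds.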